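The compounds below may be only part of what the source reports. "The series", "measured", "known", "first", "only" and "open" are said of these compounds alone.

In an ADME assay (liver) for metabolic stability, with Liver microsome (Rattus norvegicus) as the target, using microsomes and NADPH, with a stated time of 30 min (on this read-out lower numbers stand for slow clearance and higher numbers for fast clearance), three compounds with a shared core have been measured. Compound 1 (`CC#C[C@H]1CN(S(=O)(=O)c2ccc(N)nc2)CCN1c1ccc(S(N)(=O)=O)cc1`) gives 30 mL.min-1.g-1, compound 2 (`CC#CCC(O)(c1ccc(N2CCN(S(=O)(=O)c3ccc(N)nc3)C[C@@H]2C#CC)cc1)C(F)(F)F`) gives 115 mL.min-1.g-1 and compound 3 (`CC#C[C@H]1CN(S(=O)(=O)c2ccc(N)nc2)CCN1c1ccc(S(=N)(=O)C2CC2)cc1`) gives 23 mL.min-1.g-1. Compound 3 therefore shares the low end of this range with compound 1, and compound 2 stands apart. The measured gaps are a 1.3-fold lower number from compound 1 to compound 3 (0.12 log units; within the scatter) and a 5.0-fold lower number from compound 2 to compound 3 (0.70 log units; beyond the scatter).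

Compound 4 (`CC#C[C@H]1CN(S(=O)(=O)c2ccc(N)nc2)CCN1c1ccc([C@](O)(CO)C(F)(F)F)cc1`) has not yet been measured. It carries 1,2-dihydroxy-1-(trifluoromethyl)ethyl on an aromatic carbon, para to a large group: a group of 8 heavy atoms (3 carbon, 2 oxygen, 3 fluorine; no ring) in place of a group of 6 heavy atoms (3 carbon, 1 nitrogen, 1 oxygen, 1 sulfur; one three-membered non-aromatic ring of carbon only), on an aromatic carbon.

All three measured steps change the group at this same place. The closest guide is compound 2, which also carries a trifluoromethyl group and an oxygen there, and its step is a 3.8-fold higher number from compound 1 to compound 2 (0.58 log units; beyond the scatter). Compound 4 has the shorter chain, however, and the data do not separate the effect of chain length from that of the other features. A small rise is therefore expected, with no clear step beyond the scatter. The expected step is a 1.3-fold higher number from compound 3 to compound 4 (0.12 log units; within the scatter). For compound 4 the estimated value is 30 mL.min-1.g-1, with an expected range of 12 mL.min-1.g-1 to 75 mL.min-1.g-1.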

Compound 4, intrinsic clearance in microsomes: < 14 mL.min-1.g-1
Compound 4: only a limit was reported; the forecaster's own chance of this, stated with the estimate: 10%; middle value at least 2.1-fold (0.33 log units) from the limit.
By their numbers in this assay, from the lowest: compounds 3 and 1 (each within the scatter of the next); then compound 2. At a limit, below all of these: compound 4.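

In this assay compound 4 is reported only as a limit, not as a number: the limit of < 14 mL.min-1.g-1 in this assay, at which 1 of the 4 values shown sits. A trifluoromethyl group on the aromatic carbon's substituent does not by itself bring a high number, as the step of an at least 8.2-fold lower number from compound 2 to compound 4 (0.91 log units; beyond the scatter) shows. The 1,2-dihydroxy-1-(trifluoromethyl)ethyl group also separates from sulfamoyl, with an at least 2.1-fold lower number from compound 1 to compound 4 (0.33 log units; beyond the scatter), whereas against the group of compound 3 the step is an at least 1.6-fold lower number from compound 3 to compound 4 (0.21 log units; that floor lies within the scatter), so only a floor within the scatter is known there.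

The compounds shown do not tell whether the shorter chain or the second hydroxyl accounts for the gap to the group of compound 2, and the true value of compound 4 remains unknown. Going by these compounds, how an amine or a carboxylic acid at this place would read also stays open.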